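A few compounds are considered here, and "the series" means these few. Any claim that something is new, unique, unknown or untested is made for them only; others in the source may bear on it.

Working notes. Among the measured compounds shown here, compound 1 `COc1ccc(F)cc1CNCCCNc1ccnc2cc(C3CCCCC3)ccc12` gives 2290 nM in an ADME assay on HepG2 cells (Homo sapiens) for cytotoxicity, read by luminescence, CellTiter-Glo and ATP content, with a stated time of 72 h (a higher number here means that more compound is needed for the effect, a lower number that less compound is needed), the lowest of the two numbers so far. For the measured compounds named here, compound 2 `Cc1cc(C)cc(Cc2ccc3c(NCCCNCc4ccco4)ccnc3c2)c1` gives 6270 nM in this assay, a difference beyond the scatter; no single-point step connects the two. Compound 3 `COc1ccc(F)cc1CNCCCNc1ccnc2cc(-c3ccccc3)ccc12` is not yet measured; relative to compound 1 the change is phenyl in place of cyclohexyl on an aromatic carbon. Going by the values given here, no measured pair isolates this change, so only a modest step is expected in this assay: the step from compound 1 to compound 3 is estimated at a 1.3-fold higher number from compound 1 to compound 3 (0.12 log units; within the scatter), likely within the scatter. Compound 3 is expected at 3000 nM, with a range of 1200 nM to 8000 nM.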

Compound 3, half-maximal effective concentration: 2960 nM
The estimate for compound 3 lay 1.0-fold (0.01 log units) above the measured number; the range from low to high includes it.
By their numbers in this assay, from the lowest: compounds 1 and 3 (each within the scatter of the next); then compound 2.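

Phenyl in place of cyclohexyl on an aromatic carbon gives a 1.3-fold higher number from compound 1 to compound 3 (0.11 log units; within the scatter) in this assay, the first comparison in the series that isolates a single place. At this position of the shared core, the aromatic and the non-aromatic six-membered carbon rings are therefore not told apart by this read-out. Nothing available gives a reason for this result. Still open, from the compounds shown here alone, is whether a methyl group, an amine or a carboxylic acid in place of the ring would shift the number beyond the scatter.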